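Benzyl for Indanyl on the Piperidine Amine

A few compounds are considered here, and "the series" means these few. Any claim that something is new, unique, unknown or untested is made for them only; others in the source may bear on it.

Among the compounds with values here, compound 3 `c1ccc2c(c1)CCC2NC1CCN(CCCc2c[nH]c3ccc(-n4cnnc4)cc23)CC1` gives 25 nM in an assay on CHO cells for agonist activity at 5-hydroxytryptamine receptor 1D (Homo sapiens), read by GTPgammaS binding (on this read-out lower numbers stand for an effect already at smaller amounts and higher numbers for an effect only at larger amounts of compound), the highest of the three numbers measured so far. Compound 1 `O=S(=O)(NCC1CCN(CCCc2c[nH]c3ccc(-n4cnnc4)cc23)CC1)c1ccccc1` gives 12 nM, and compound 2 `CN(Cc1cccs1)C1CCN(CCCc2c[nH]c3ccc(-n4cnnc4)cc23)CC1` gives 3.5 nM. Compound 4 `c1ccc(CNC2CCN(CCCc3c[nH]c4ccc(-n5cnnc5)cc34)CC2)cc1` differs from compound 3 by benzyl in place of 2,3-dihydro-1H-inden-1-yl on an amine nitrogen. The step that bears most closely on this change is a 7.1-fold higher number from compound 2 to compound 3 (0.85 log units; beyond the scatter), in which an arylmethyl amine became the indanyl amine; the reverse direction is what compound 4 approaches, though it keeps a secondary amine rather than a methylated one, and a 2.1-fold higher number from compound 1 to compound 3 (0.32 log units; beyond the scatter) also shows the indanyl amine among the weaker variants. A modest improvement is therefore expected for compound 4, estimated at 8 nM with a range of 3 nM to 22 nM, corresponding to an expected step of a 3.1-fold lower number from compound 3 to compound 4 (0.49 log units; beyond the scatter).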

Compound 4, half-maximal effective concentration: 7.6 nM
The estimate for compound 4 lay 1.1-fold (0.02 log units) above the measured number; low and high end bracket the measured number.
By their numbers in this assay, from the lowest: compound 2; then compounds 4 and 1 (each within the scatter of the next); then compound 3.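

In this assay, benzyl in place of 2,3-dihydro-1H-inden-1-yl on the amine nitrogen gives a 3.3-fold lower number from compound 3 to compound 4 (0.52 log units; beyond the scatter), the first step shown that alters this substituent while the secondary amine stays. That benzylamino compound still does not reach the methyl((thiophen-2-yl)methyl)amino compound, with a 2.2-fold higher number from compound 2 to compound 4 (0.34 log units; beyond the scatter), whereas a 1.6-fold lower number from compound 1 to compound 4 (0.20 log units; within the scatter) leaves it level with the ((phenylsulfonyl)amino)methyl compound. Nothing available explains these differences. Open, as far as these compounds go, is whether a methoxy group or a fluorine on the benzyl ring, or a methyl on the benzylamine nitrogen, would move the number in either direction.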